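A few compounds are considered here, and "the series" means these few. Any claim that something is new, unique, unknown or untested is made for them only; others in the source may bear on it.

Working notes on the arylsulfonate series, antiproliferative read-out.

Of the compounds shown here, two carry numbers so far. Among the measured compounds shown here, compound 1 `CC(C)C(=O)Nc1ccc(S(=O)(=O)Oc2ccccc2I)cc1` and compound 2 `CC(C)c1ccccc1OS(=O)(=O)c1ccc(NC(=O)C(C)(C)C)cc1` share the same sulfonate core but differ at two places at once, one on the amide and one on the phenol ring, so no single-change step between them can be drawn; only their values are stated. In a functional assay on M21 cells (Homo sapiens) for antiproliferative activity, read by sulforhodamine B assay, with a stated time of 48 h (on this read-out lower numbers stand for stronger inhibition and higher numbers for weaker inhibition), compound 1 gives 13000 nM. In this assay compound 2 gives 6200 nM, the lowest of the two numbers, with compound 1 standing beyond the scatter from it.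

The next compound, compound 3 `CC(C)(C)C(=O)Nc1ccc(S(=O)(=O)Oc2ccccc2I)cc1`, is drawn from compound 2 by one change: iodo in place of isopropyl on an aromatic carbon. Compound 3 thus keeps the pivalamide of compound 2 and takes the iodo substituent that compound 1 carries, so it sits between the two measured compounds in structure. For the measured compounds named here, with no measured single-change step available for guidance, the step from compound 2 to compound 3 is expected to be small and toward a somewhat higher number, a 1.5-fold higher number from compound 2 to compound 3 (0.16 log units; within the scatter), given that compound 1 with the iodo group gives 13000 nM. Compound 3 is therefore estimated at 9000 nM in this assay, within a range of 3000 nM to 27000 nM.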

Compound 3, half-maximal inhibitory concentration: 8300 nM
For compound 3 the middle estimate is 1.1-fold (0.04 log units) above the measured one; the range from low to high includes it.
By their numbers in this assay, from the lowest: compounds 2, 3 and 1 (each within the scatter of the next, the first and the last beyond it).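

With the pivalamide held fixed, iodo in place of isopropyl on this aromatic carbon, ortho to a large group, gives a 1.3-fold higher number from compound 2 to compound 3 (0.13 log units; within the scatter) in this assay, so the two groups cannot be told apart here on this read-out, although isopropyl has 3 heavy atoms and iodo has 1. With the iodo group held fixed, the amide side gives the same kind of result: methyl in place of hydrogen on a saturated chain carbon bound to a carbonyl carbon gives a 1.6-fold lower number from compound 1 to compound 3 (0.19 log units; within the scatter), and this change also stays inside the usual spread of repeated measurements. No measurement to hand bears on why either step is this small.

Open, as far as these compounds go, is whether an amine or a carboxylic acid on this aromatic carbon, where only isopropyl and iodo appear so far, gives a number clearly apart from those of compound 2 and compound 3. Also open, from the compounds shown here alone, is whether a longer chain on the amide carbonyl departs from the two branched amides seen here.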